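This account rests on a few compounds, and the source may have more. Where it says the series, first, only, none or still open, it means among the compounds named here.

Compound 3, `CC(=O)c1ccc(NC(=O)CSc2nnc(-c3ccoc3C)n2Cc2ccco2)cc1`, is the only one of the three measured compounds with a number in a functional assay on CHO cells for antagonist activity at Orexin/Hypocretin receptor type 1 (Homo sapiens), read by FLIPR and calcium flux; a lower number here means a stronger inhibitor, a higher number a weaker inhibitor: compound 3 gives 2510 nM. Compound 1, `Cc1cccc(C)c1NC(=O)CSc1nnc(-c2ccoc2C)n1Cc1ccco1`, gives > 15800 nM in this assay, which is a limit of the assay rather than a number. Compound 2, `COc1ccccc1NC(=O)CSc1nnc(-c2ccoc2C)n1Cc1ccco1`, likewise gives > 15800 nM in this assay, again a limit. Both these limits sit at the limit of > 15800 nM in this assay, at which 2 of the 3 values shown sit, so the step that the two limits leave unreadable from compound 1 to compound 2 cannot be read.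

Compound 4, `CC(=O)c1cccc(NC(=O)CSc2nnc(-c3ccoc3C)n2Cc2ccco2)c1`, is not yet measured. It differs from compound 3 by 3-acetylphenyl in place of 4-acetylphenyl on an amide-type nitrogen, so the two have the same atoms joined differently.

The measured steps that touch the aryl group on the amide-type nitrogen are an at least 6.2-fold lower number from compound 1 to compound 3 (0.79 log units; beyond the scatter) and an at least 6.2-fold lower number from compound 2 to compound 3 (0.79 log units; beyond the scatter). Both show that the 4-acetylphenyl group gives a lower number than a 2,6-dimethylphenyl or 2-methoxyphenyl group, but neither step moves the acetyl group around the ring, so they give no direct reading for the change to compound 4. For the measured compounds named here, the expected step of a 2.0-fold higher number from compound 3 to compound 4 (0.30 log units; within the scatter) is therefore uncertain, with a lean toward a somewhat higher number, since the only group with a number is the one being moved.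

Compound 4 is estimated at 5000 nM, with a range from 1500 nM to 15800 nM.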

Compound 4, inhibition constant: 3160 nM
Compound 4: the middle estimate sits 1.6-fold (0.20 log units) above what was measured, and the stated range covers the measured number.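

In this assay, moving the acetyl group around the aryl ring gives a 1.3-fold higher number from compound 3 to compound 4 (0.10 log units; within the scatter), so 3-acetylphenyl and 4-acetylphenyl on the amide-type nitrogen cannot be told apart at this position. For the compounds shown here, earlier, 4-acetylphenyl was the only aryl group with a number; now a second acetylphenyl group has one, and it too stands clear of the two other aryl groups, with an at least 5.0-fold lower number from compound 2 to compound 4 (0.69 log units; beyond the scatter) and an at least 5.0-fold lower number from compound 1 to compound 4 (0.69 log units; beyond the scatter). These last two steps give only a minimum size, because each starts from a limit of the assay and not from a number: the limit of > 15800 nM in this assay, at which 2 of the 4 values shown sit.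

From the compounds shown here alone, whether the acetyl group itself is what matters at this position stays open, for instance whether a nitrile or a carboxylic acid in its place on the aryl ring would keep a value close to those of compound 3 and compound 4. Going by these compounds, the core is the same in all four compounds, so it is also open how a change there, such as an added amine, would affect the value.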